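The compounds below may be only part of what the source reports. "The series", "measured", "known", "first", "only" and "open" are said of these compounds alone.

Three compounds share a core built from two aryl rings on a five-membered aromatic ring that carries a sulfur-linked side chain, and they differ in what that side chain carries. Compound 1 `Cc1cccc(-c2nc(SC[C@H]3C[C@@](C)(O)CC(=O)O3)[nH]c2-c2cccc(C)c2)c1.Cc1cccc(-c2nc(SC[C@H]3C[C@](C)(O)CC(=O)O3)[nH]c2-c2cccc(C)c2)c1` is one of them. In an assay on microsomes from liver for inhibition of sterol O-acyltransferase 1 (Rattus norvegicus) (a lower number here means a stronger inhibitor, a higher number a weaker inhibitor), compound 1 gives 64 nM. Compound 2 `C[C@@]1(O)CC(=O)OC(CSc2nc(-c3ccccc3Cl)c(-c3ccccc3Cl)[nH]2)C1` gives 140 nM in this assay, and compound 3 `CO[C@H]1C[C@H](O)C[C@@H](CSc2nc(-c3ccccc3)c(-c3ccccc3)[nH]2)O1` gives 90 nM in this assay. Among these three numbers, the value of compound 3 is the second highest; its gap to compound 1 and its gap to compound 2 both lie within the usual scatter of repeated measurements, so none of the three can be told apart with confidence.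

Compound 4 `c1ccc(-c2nc(SCC3CCCCC3)[nH]c2-c2ccccc2)cc1` has not yet been measured. It differs from compound 3 in one place: a group of 6 heavy atoms (6 carbon; one six-membered non-aromatic ring of carbon only) in place of a group of 9 heavy atoms (6 carbon, 3 oxygen; one six-membered non-aromatic ring with 1 hetero atom), on a saturated chain carbon bound to a sulfur. The oxygen-bearing ring with its hydroxyl and methoxy groups is thus replaced by a plain carbon ring of the same size.

Among the measured compounds shown here, no measured pair in this set shows what such a change does, so the expectation rests on the structures alone. Compound 4 is expected to give 220 nM, within a range from 60 nM to 800 nM. The step is estimated as a 2.4-fold higher number from compound 3 to compound 4 (0.39 log units; beyond the scatter), towards a weaker inhibitor, most likely somewhat beyond the scatter but not by a large margin.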

Compound 4, half-maximal inhibitory concentration: 100 nM
Beside the measured number, compound 4's estimate is 2.2-fold (0.34 log units) above it; measured number inside the range.
By their numbers in this assay, from the lowest: compounds 1, 3, 4 and 2 (each within the scatter of the next, the first and the last beyond it).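

In this assay, replacing the oxygen-bearing ring with cyclohexyl on a saturated chain carbon bound to a sulfur gives a 1.1-fold higher number from compound 3 to compound 4 (0.05 log units; within the scatter) and so leaves the two compounds indistinguishable. Among the compounds shown here, this is the first direct comparison at this position, since the earlier compounds differed in more than one place and could not isolate a single change. For this pair, a plain carbon ring without hydrogen-bond donors, hydrogen-bond acceptors or defined stereocentres gives a number that cannot be told apart from that of the more elaborate ring, though no supporting measurement here explains this result.

The compounds shown leave open whether the position tolerates a very different group, such as a carboxylic acid, an amine or a longer open chain in place of the ring on that carbon. This single pair also cannot show whether the same swap would behave alike on the differently substituted aryl rings of compound 1 or compound 2.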